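Shifting the aryl group along the chain of a shared core

The source may report more compounds than this note shows. Statements on the series, on what has been measured and on what is new or still open speak of the compounds shown alone.

Measured so far:
compound 1, `COc1cccc(CCC(=O)Nc2nc3ccccc3c(=O)s2)c1`, 95.3 nM
compound 2, `O=C(CCCc1ccc(Cl)c(Cl)c1)Nc1nc2ccccc2c(=O)s1`, 3440 nM
compound 3, `O=C(CCc1ccccc1Br)Nc1nc2ccccc2c(=O)s1`, 2.09 nM

In an in vitro assay on cells for inhibition of Amine oxidase [flavin-containing] B (Homo sapiens), read by fluorescence and Amplex Red, with stated times of 30 min and 45 min (on this read-out lower numbers stand for stronger inhibition and higher numbers for weaker inhibition), compound 3 gives the lowest of the three numbers. Its nearest neighbour is compound 1, and the step of a 46-fold lower number from compound 1 to compound 3 (1.66 log units; beyond the scatter) lies beyond the scatter; compound 2 is furthest away, with its own value standing far above that of compound 3.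

Compound 4, `O=C(CCCc1cccc(Cl)c1)Nc1nc2ccccc2c(=O)s1`, has not yet been measured. Compared with compound 3 it carries 3-chlorobenzyl in place of 2-bromophenyl on a saturated chain carbon, two bonds along the chain from a carbonyl carbon. Within the data shown here, only one measured step touches this position, a 46-fold lower number from compound 1 to compound 3 (1.66 log units; beyond the scatter), and it shows that the aryl group at this chain carbon can move the number a great deal. Compound 2, which also carries a chain one carbon longer with a chlorinated ring, stands well above compound 3 in this assay, and compound 1 with a different ring pattern also stands above it. The expectation is therefore a step upward, toward weaker inhibition, expected to be about a 240-fold higher number from compound 3 to compound 4 (2.38 log units; beyond the scatter). Compound 4 is estimated to give 500 nM in this assay, with a range from 60 nM to 4000 nM.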

Compound 4, half-maximal inhibitory concentration: > 1000 nM
Compound 4: only a limit was reported; the forecaster's own chance of this, stated with the estimate: 5%; at least 2.0-fold (0.30 log units) between middle value and limit.
By their numbers in this assay, from the lowest: compound 3; then compound 1; then compound 2.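

In this assay compound 4 is reported only as a limit and not as a number: the limit of > 1000 nM in this assay, at which 1 of the 4 values shown sits.

Even so, the limit fixes a direction and a least size at this chain carbon, with 3-chlorobenzyl entering in place of 2-bromophenyl in an at least 470-fold higher number from compound 3 to compound 4 (2.67 log units; beyond the scatter) and in place of 3-methoxyphenyl in an at least 10-fold higher number from compound 1 to compound 4 (1.02 log units; beyond the scatter). The earlier compounds had shown that the aryl group at this position can move the number a great deal, and compound 4 now shows that 3-chlorobenzyl gives up much of what both aryl groups of compound 3 and compound 1 hold, while the step between compound 2 and compound 4, hydrogen in place of chloro on an aromatic carbon, cannot be read.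

The compounds shown leave open whether the loss goes with the extra carbon of the benzyl group or with the change of ring substituent, a question that a 2-bromobenzyl or a 3-chlorophenyl group at this chain carbon would separate. They also leave open how an amine or a carboxylic acid on the aromatic ring would read in this assay.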